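The source may hold more compounds than are shown below. What is called first, only, known or untested is meant among the compounds shown, and "the series" means these compounds.

Measured so far in a functional assay on PC-3 cells (Homo sapiens) for inhibition; a lower number here means a stronger inhibitor, a higher number a weaker inhibitor:
compound 1 `COc1cc2nc(N3CCN(S(=O)(=O)c4ccc(I)cc4)CC3)nc(N)c2cc1OC` gives 15000 nM;
compound 2 `COc1cc2nc(N3CCN(S(=O)(=O)c4ccc(C)cc4)CC3)nc(N)c2cc1OC` gives 30000 nM;
compound 3 `COc1cc2nc(N3CCN(S(=O)(=O)c4ccc(C(C)(C)C)cc4)CC3)nc(N)c2cc1OC` gives 4100 nM.

Compound 3 holds the lowest number of the three. The step of a 3.7-fold lower number from compound 1 to compound 3 (0.56 log units; beyond the scatter) and the step of a 7.3-fold lower number from compound 2 to compound 3 (0.86 log units; beyond the scatter) both lie beyond the scatter, so the group on the aryl ring of the sulfonyl does move the number in this assay, whereas a 2.0-fold higher number from compound 1 to compound 2 (0.30 log units; within the scatter) stays within the scatter.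

Compound 4 `COc1cc2nc(N3CCN(S(=O)(=O)c4cccc(C(=O)O)c4)CC3)nc(N)c2cc1OC` differs from compound 3 by 3-carboxyphenyl in place of 4-(tert-butyl)phenyl on a sulfonyl sulfur. Going by the values given here, no measured step covers this change: every measured step exchanges one group for another on an aromatic carbon, and none brings in a carboxylic acid, a hydrogen-bond donor or a hydrogen-bond acceptor. What the measured steps do show is that the two other groups tried, in compounds 1 and 2, sit at higher numbers than the tert-butyl group of compound 3. The carboxyphenyl is a group of a kind not yet tried, so the expectation is a number rising back toward those of compounds 1 and 2, with wide uncertainty.

Compound 4 is therefore expected at 20000 nM, in the range 5000 nM to 80000 nM. That estimate means an expected step of a 4.9-fold higher number from compound 3 to compound 4 (0.69 log units; beyond the scatter) in this assay.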

Compound 4, half-maximal inhibitory concentration: 53000 nM
Compound 4: the middle estimate sits 2.7-fold (0.42 log units) below what was measured; the measured number falls inside the stated range.
By their numbers in this assay, from the lowest: compound 3; then compounds 1, 2 and 4 (each within the scatter of the next, the first and the last beyond it).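

In this assay, 3-carboxyphenyl on the sulfonyl sulfur brings the first hydrogen-bond donor and acceptor to this place in the series, and against 4-(tert-butyl)phenyl the change gives a large step (a 13-fold higher number from compound 3 to compound 4 (1.11 log units; beyond the scatter)). Against the other two aryl groups the picture is mixed: the step from 4-methylphenyl stays within the scatter (a 1.8-fold higher number from compound 2 to compound 4 (0.25 log units; within the scatter)), while the step from 4-iodophenyl lies beyond it (a 3.5-fold higher number from compound 1 to compound 4 (0.55 log units; beyond the scatter)), so the carboxylic acid does not separate compound 4 from every other compound. Going by these compounds alone, compound 3 is now the only compound whose steps to all the others lie beyond the scatter, and nothing at hand bears on the reason for these steps.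

The names of the groups show that compound 4 differs from compound 3 both in the group and in where it stands on the ring, so the shown compounds cannot separate the effect of the carboxylic acid from that of its place. A methyl ester in place of the carboxylic acid, or a cyclohexyl group in place of the tert-butyl group, would test how far each of these two readings holds.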